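This account rests on a few compounds, and the source may have more. Where it says the series, first, only, none or still open, it means among the compounds named here.

The measured compounds:

compound 1, `COc1ccc(C2CC(c3cccc4ccccc34)=NN2C(C)=O)c(OC)c1OC`, 1790 nM
compound 2, `CC(=O)N1N=C(c2cccc3ccccc23)CC1c1cccc(Br)c1`, 11900 nM
compound 3, `O=CCN1N=C(c2ccc3ccccc3c2)CC1c1ccccc1[N+](=O)[O-]`, 3360 nM

In a functional assay on IMR-32 cells (Homo sapiens) for cytotoxicity, read by sulforhodamine B assay, with a stated time of 48 h (a higher number here means a weaker inhibitor, a lower number a stronger inhibitor), compound 3 gives 3360 nM, the second highest of the three numbers. Its nearest neighbour is compound 1 with 1790 nM, a lower number but one that lies within the scatter of the method, so the two cannot be told apart. Its furthest neighbour is compound 2 with 11900 nM, a higher number that lies beyond the scatter, so compound 3 is the stronger inhibitor of that pair.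

Compound 4, `O=CCN1N=C(c2ccc3ccccc3c2)CC1/C=C/c1ccccc1`, has not yet been measured in this assay. It differs from compound 3 in one place: 2-phenylethenyl in place of 2-nitrophenyl on a saturated ring carbon. The core and the formylmethyl group on the ring nitrogen are unchanged.

For the measured compounds named here, no pair of measured compounds shows this kind of change, so there is no measured step to lean on. The three numbers span a modest range, and the exchange of one substituent for another on the same saturated ring carbon gives no reason to expect a departure from that range. Compound 4 is therefore expected to land near compound 3, at an estimated 4000 nM, with a range from 1500 nM to 12000 nM. The estimate implies a step of a 1.2-fold higher number from compound 3 to compound 4 (0.08 log units; within the scatter), which may well stay within the scatter.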

Compound 4, half-maximal inhibitory concentration: 17200 nM
Compound 4: the middle estimate sits 4.3-fold (0.63 log units) below what was measured, outside the stated range (above it).
By their numbers in this assay, from the lowest: compounds 1 and 3 (each within the scatter of the next); then compounds 2 and 4 (each within the scatter of the next).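

In this assay, the saturated ring carbon next to the ring nitrogen proves sensitive to what it carries: with the core and the formylmethyl group unchanged, 2-phenylethenyl in place of 2-nitrophenyl gives a 5.1-fold higher number from compound 3 to compound 4 (0.71 log units; beyond the scatter). For the compounds shown here, this is the first step measured at this position, and it shows that two groups with much in common can still be told apart here, since each holds one six-membered aromatic ring of carbon only and 1 double bond outside aromatic rings, while the entering group is all carbon and the leaving group holds nitrogen and oxygen. No measurement shown here accounts for the weaker inhibition by compound 4.

Going by these compounds alone, the single step bundles two differences, the loss of the nitro group and the different attachment of the aromatic ring to the saturated ring carbon, and it cannot separate them. On these data alone, how a plain phenyl, an aminophenyl or a saturated two-carbon chain ending in phenyl would behave on this carbon remains open, as does whether the step would hold with an acetyl group in place of formylmethyl on the ring nitrogen.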